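A Second Propargyl Group Replaces the Benzyl Group

A few compounds are considered here, and "the series" means these few. Any claim that something is new, unique, unknown or untested is made for them only; others in the source may bear on it.

Compound 1, `C#CCN(C)Cc1cn(-c2cc(NC(=S)NCC)ncn2)cn1`: 20.2%
Compound 2, `C#CCN(CC)Cc1cn(-c2cc(NC(=S)NCC)ncn2)cn1`: 6.71%
Compound 3, `C#CCN(Cc1ccccc1)Cc1cn(-c2cc(NC(=S)NCC)ncn2)cn1`: 17.8%

These three compounds share one core and differ only in the group on a saturated chain carbon bound to an amine nitrogen. In an assay on isolated protein for inhibition of Amine oxidase [flavin-containing] A (Homo sapiens), read by fluorescence and Amplex Red, with a stated time of 15 min, tested at 50 uM (a higher number here means more inhibition at the concentration tested (going by the name of the read-out), a lower number less inhibition), compound 1 gives 20.2%, compound 2 gives 6.71%, and compound 3 gives 17.8%. Compound 3 therefore stands second highest of the three: the step of a number 2.4 percentage points lower from compound 1 to compound 3 (within the scatter) is within the scatter, while the step of a number 11.1 percentage points higher from compound 2 to compound 3 (beyond the scatter) is beyond it.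

Compound 4, `C#CCN(CC#C)Cc1cn(-c2cc(NC(=S)NCC)ncn2)cn1`, differs from compound 3 by ethynyl in place of phenyl on a saturated chain carbon bound to an amine nitrogen. All three measured steps change the group at this same place, so they show how much this position can move the read-out: a number 13.5 percentage points lower from compound 1 to compound 2 (beyond the scatter), a number 11.1 percentage points higher from compound 2 to compound 3 (beyond the scatter), and a number 2.4 percentage points lower from compound 1 to compound 3 (within the scatter). None of them places an ethynyl group there, so the direction of the new step cannot be read from them. Their sizes suggest that any change in this assay should be modest rather than large.

Compound 4 is expected to sit close to compound 3, with an expected step of a number 2.8 percentage points lower from compound 3 to compound 4 (within the scatter). The estimate for compound 4 in this assay is 15%, with a range from 3% to 30%.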

Compound 4, a percentage reported as inhibition, at one concentration (the size of the read-out at that concentration, not a potency): 15.5%
Beside the measured number, compound 4's estimate is 0.5 percentage points below it; the measured number falls inside the stated range.
By their numbers in this assay, from the lowest: compounds 2, 4, 3 and 1 (each within the scatter of the next, the first and the last beyond it).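

In this assay, replacing phenyl with ethynyl, the same difference as benzyl to propargyl, gives a number 2.3 percentage points lower from compound 3 to compound 4 (within the scatter) and so shows that a group with no ring can stand at this place on a saturated chain carbon bound to an amine nitrogen and leave the read-out within the scatter of compound 3. Going by these compounds alone, the other two new steps add a point that the earlier compounds could not show: a number 8.8 percentage points higher from compound 2 to compound 4 (within the scatter) and a number 4.7 percentage points lower from compound 1 to compound 4 (within the scatter) both stay within the scatter, so compound 4 cannot be grouped with either compound 1 or compound 2, even though those two lie beyond the scatter of each other. No measurement offered here explains why the swap of phenyl for ethynyl leaves the number within the scatter.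

The compounds shown leave open how a carboxylic acid, a longer chain such as butyl, or a cyclohexyl ring would read at this place. Each number is also a single reading at one concentration, so how these compounds compare in potency remains an open question.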